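The compounds below may be only part of what the source reports. "The series", "measured", "known", "first", "only" and "open" are said of these compounds alone.

Measured so far in a functional assay on HepG2 cells (Homo sapiens) for antiproliferative activity, read by colorimetric assay and MTT assay, with a stated time of 48 h; on this read-out higher numbers stand for weaker inhibition and lower numbers for stronger inhibition:

- compound 1 `O=C(NS(=O)(=O)c1ccccc1)c1cccnc1` gives 10400 nM
- compound 2 `Cc1ccc(S(=O)(=O)NC(=O)c2cccnc2)cc1` gives 12300 nM
- compound 3 `O=C(NS(=O)(=O)c1ccc(F)cc1)c1cncc(C(=O)NS(=O)(=O)c2ccc(F)cc2)c1` gives 6200 nM

Compound 2 at 12300 nM lies within the scatter of compound 1 and also of compound 3, so no order can be read from either pair. Compound 4 `Cc1ccc(S(=O)(=O)NC(=O)c2ccccn2)cc1` has the same atoms as compound 2, joined differently: pyridin-2-yl in place of pyridin-3-yl on a carbonyl carbon.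

Among the measured compounds shown here, only one measured step links two compounds that differ in one place, and it is a different change. That step, a 1.2-fold higher number from compound 1 to compound 2 (0.07 log units; within the scatter), is methyl in place of hydrogen on an aromatic carbon. For the measured compounds named here, no measured compound carries pyridin-2-yl, so the data offer no direct precedent for this exchange and point to no direction. No step beyond the scatter is therefore expected in this assay, although the missing precedent keeps the range wide. The expected change is a 1.1-fold lower number from compound 2 to compound 4 (0.05 log units; within the scatter) and it is an estimate resting on compound 2 alone. For compound 4 the estimated value is 11000 nM with an expected range from 5000 nM to 25000 nM in this read-out.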

Compound 4, half-maximal inhibitory concentration: 12100 nM
For compound 4 the middle estimate is 1.1-fold (0.04 log units) below the measured one; measured number inside the range.
By their numbers in this assay, from the lowest: compounds 3, 1, 4 and 2 (each within the scatter of the next).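

In this assay, pyridin-2-yl in place of pyridin-3-yl on a carbonyl carbon gives a 1.0-fold lower number from compound 2 to compound 4 (0.01 log units; within the scatter) and so leaves the two groups indistinguishable in this pair. Among the compounds shown here, the only earlier step, a 1.2-fold higher number from compound 1 to compound 2 (0.07 log units; within the scatter), concerned methyl in place of hydrogen on an aromatic carbon, so this is the first reading of any change on the carbonyl carbon, and it too stays within the scatter. Nothing on hand offers a reason for this result. Still open, as far as these compounds go, is whether pyridin-4-yl or a piperidine on the same carbonyl carbon would move the number beyond the scatter of compound 2 in this read-out. Equally open, from the compounds shown here alone, is whether the exchange of pyridin-3-yl for pyridin-2-yl would read the same way with a methoxy group or a chlorine in place of the methyl carried by compound 2 and compound 4.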